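A few compounds are considered here, and "the series" means these few. Any claim that something is new, unique, unknown or untested is made for them only; others in the source may bear on it.

Working notes on the series

Compound 1 `CCCCc1ccc(-c2c(C)[nH]c(=O)n2C)cc1` and compound 2 `CCCCCCc1ccc(-c2c(C)[nH]c(=O)n2C)cc1` share one core; compound 3 `CCCCCCCCOc1ccc(-c2c(C)[nH]c(=O)n2C2CCCCC2)cc1` and compound 4 `CCCCCCCCCCOc1ccc(-c2c(C)[nH]c(=O)n2C2CCCCC2)cc1` share another. In a functional assay on the whole organism with Rattus norvegicus as the target (a higher number here means that more compound is needed for the effect, a lower number that less compound is needed), compound 1 gives 0.1 mg/kg. In this assay compound 2 gives 0.3 mg/kg. In this assay compound 3 gives 30 mg/kg; compound 3 stands highest of the three numbers, with compound 2 nearest and compound 1 furthest. The difference between the core of compound 1 and the core of compound 3 is not broken down here.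

The measured step within the first pair is ethyl in place of hydrogen on a saturated chain carbon, four bonds along the chain from an aromatic carbon, and it gave a 3.0-fold higher number from compound 1 to compound 2 (0.48 log units; beyond the scatter). Compound 4 is not yet measured. It differs from compound 3 by ethyl in place of hydrogen on a saturated chain carbon, eight bonds along the chain from an oxygen on an aromatic ring. Among the compounds with values here, this is the same kind of change as the one from compound 1 to compound 2, not the same change: in the first pair the ethyl enters four bonds along the chain from an aromatic carbon, in the second pair eight bonds along the chain from an oxygen on an aromatic ring, and the two cores differ as well. Only one earlier instance of this change exists among the compounds shown, so the expectation rests on it alone.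

A step of similar direction and size is expected, a 2.5-fold higher number from compound 3 to compound 4 (0.40 log units; beyond the scatter), because the earlier instance gave a 3.0-fold higher number from compound 1 to compound 2 (0.48 log units; beyond the scatter). Compound 4 is accordingly expected to give about 75 mg/kg in this assay, within a range from 30 mg/kg to 300 mg/kg.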

Compound 4, minimum effective dose: 0.1 mg/kg
Compound 4: middle estimate off by 750-fold (2.88 log units), on the high side, outside the stated range (below it).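

In this assay, the new step on the core of compound 3 is a 300-fold lower number from compound 3 to compound 4 (2.48 log units; beyond the scatter), opposite in direction to the earlier step on the core of compound 1 and much larger. Within these two pairs, ethyl in place of hydrogen does not carry over from one core to the other, as the two steps differ well beyond what repeated measurement would explain: the same change on two cores in this assay, a 3.0-fold higher number (0.48 log units; beyond the scatter) from compound 1 to compound 2 and a 300-fold lower number (2.48 log units; beyond the scatter) from compound 3 to compound 4, 900-fold (2.95 log units) apart, beyond the scatter of two such steps

This does not show what sets the two steps apart, since each rests on a single pair and the pairs differ in the core, in the place of the change along the chain, and in whether the chain is joined through an oxygen on an aromatic ring, so no general rule for either core follows from them.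

The compounds shown leave open whether a longer chain on the core of compound 3 would keep the low number of compound 4, at 0.1 mg/kg, or lose it again. They also leave open whether an ethyl placed eight bonds along the chain on the core of compound 1, or a chain carrying an amine on either core, would follow the first step, the second, or neither.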